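The compounds below may be only part of what the source reports. "The series", "measured", "known", "first", "only" and "open" are said of these compounds alone.

Measured so far:
- compound 1, `CCCCCC/C=C/C=C/C#C/C=C/C=C/COC(C)=O`, giving 11000 nM in a functional assay on HL-60 cells (Homo sapiens) for inhibition, read by MTT assay, with a stated time of 3 days; on this read-out higher numbers stand for weaker inhibition and lower numbers for stronger inhibition
- compound 2, `CCCCCCC/C=C\CC#C/C=C/C=C/COC(C)=O`, giving 11000 nM in this assay

On these numbers compound 2 stands level with compound 1: the two values agree at the digits shown, and the gap between them lies within the usual scatter of repeated measurements, so nothing can be said about which of the two is the stronger inhibitor.

Compound 3, `CC(=O)OC/C=C/C=C/C#CC/C=C\CCCCCCCCOC(C)=O`, has not yet been tested. It differs from compound 2 in one place: acetoxymethyl in place of hydrogen on a saturated chain carbon, seven bonds along the chain from a double-bonded chain carbon. The rest of the structure, the long chain with its double and triple bonds and the acetoxymethyl group at the other end, is kept as in compound 2.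

Among the measured compounds shown here, no pair of measured compounds with a single change is available to show how a change like this affects the read-out, so the expectation rests on compound 2 alone. The step of a 1.4-fold higher number from compound 2 to compound 3 (0.13 log units; within the scatter) that is expected here is small, probably not beyond the scatter, and if anything toward weaker inhibition. Compound 3 is therefore estimated at 15000 nM, with a range from 4000 nM to 50000 nM.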

Compound 3, half-maximal inhibitory concentration: > 10000 nM
Compound 3: only a limit was reported; the forecaster's own chance of this, stated with the estimate: 15%; the middle value lies beyond the limit too.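

Compound 3 is reported only as a limit of the assay, not as a number, so the size of the step from compound 2 to compound 3 cannot be read: the limit of > 10000 nM in this assay, at which 1 of the 3 values shown sits.

The compounds shown leave open how strongly compound 3 actually inhibits, and whether acetoxymethyl in place of hydrogen changes the read-out at all.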